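Working notes: from compound 3 to compound 4

This account rests on a few compounds, and the source may have more. Where it says the series, first, only, none or still open, it means among the compounds named here.

Measured in a functional assay on HeLa cells (Homo sapiens) for inhibition, read by MTT assay, with a stated time of 48 h; on this read-out lower numbers stand for stronger inhibition and higher numbers for weaker inhibition:
- compound 1 `O=C(CC(c1ccccc1)C(C(=O)Nc1ccccn1)C(=O)Nc1ccccn1)c1ccccc1`: 28100 nM
- compound 2 `O=C(CC(c1ccc(F)cc1)C(C(=O)Nc1ccccn1)C(=O)Nc1ccccn1)c1ccccc1`: 20800 nM
- compound 3 `COc1ccc(C(CC(=O)c2ccccc2)C(C(=O)Nc2ccccn2)C(=O)Nc2ccccn2)cc1`: "not active" (no number reported)

Compound 3 has no single number in this assay, so a step from it cannot be sized. Compound 4 `Cc1cc(C)c(C(CC(=O)c2ccccc2)C(C(=O)Nc2ccccn2)C(=O)Nc2ccccn2)c(C)c1` carries one change from compound 3: 2,4,6-trimethylphenyl in place of 4-methoxyphenyl on a saturated chain carbon bound to two saturated chain carbons. Among the measured compounds shown here, the only measured step is a 1.4-fold lower number from compound 1 to compound 2 (0.13 log units; within the scatter). It lies within the scatter and involves a different substitution, so it bears only loosely on this change. No step size or direction can therefore be expected from compound 3. The estimate instead rests on compound 1 at 28100 nM and compound 2 at 20800 nM, with a real chance of no number. For compound 4 the expected value is 35000 nM, with an estimated range of 15000 nM to 90000 nM.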

Compound 4, half-maximal inhibitory concentration: 15100 nM
The estimate for compound 4 lay 2.3-fold (0.37 log units) above the measured number, and the stated range covers the measured number.
By their numbers in this assay, from the lowest: compounds 4, 2 and 1 (each within the scatter of the next).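

In this assay the saturated chain carbon bound to two saturated chain carbons carries 2,4,6-trimethylphenyl and still gives a number, with a 1.4-fold lower number from compound 2 to compound 4 (0.14 log units; within the scatter) and a 1.9-fold lower number from compound 1 to compound 4 (0.27 log units; within the scatter) both within the scatter, so phenyl, 4-fluorophenyl and 2,4,6-trimethylphenyl are not separated here. The step from compound 3 cannot be read: compound 3 has only the report "not active". Nothing measured bears on why 4-methoxyphenyl gives no number here.

Open, as far as these compounds go, is whether an aminophenyl group, a carboxyphenyl group or a longer chain at this carbon gives a number, and whether any group there moves the number beyond the scatter.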